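This account rests on a few compounds, and the source may have more. Where it says the series, first, only, none or still open, it means among the compounds named here.

Measured compounds:
compound 1, `COc1cc(O)cc(O)c1C(=O)/C=C/c1ccc(O)cc1`, 48100 nM
compound 2, `COc1cc(O)cc(O)c1C(=O)/C=C/c1ccc(Cl)cc1`, 17000 nM

Among the compounds with values here, in a functional assay on HeLa cells (Homo sapiens) for inhibition, read by MTT assay, with a stated time of 72 h (a higher number here means a weaker inhibitor, a lower number a stronger inhibitor), compound 2 stands lowest of the two numbers, and the single measured step, a 2.8-fold lower number from compound 1 to compound 2 (0.45 log units; beyond the scatter), lies beyond the scatter. Compound 3, `COc1cc(O)cc(O)c1C(=O)/C=C/c1ccc([N+](=O)[O-])cc1`, differs from compound 2 in one place: nitro in place of chloro on an aromatic carbon. Within the data shown here, no measured step swaps chloro for nitro, so the step from compound 1 to compound 2 is only a loose guide, showing that a change on this aromatic carbon can move this assay modestly. For compound 3 the expected step is a 1.4-fold lower number from compound 2 to compound 3 (0.15 log units; within the scatter). Compound 3 is therefore estimated at 12000 nM, with a range from 4000 nM to 40000 nM.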

Compound 3, half-maximal inhibitory concentration: > 50000 nM
Compound 3 gave a limit, no number; the forecaster's own chance of this, stated with the estimate: 5%; middle value at least 4.1-fold (0.61 log units) away from the limit.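

Compound 3 gives only a limit, not a number: the limit of > 50000 nM in this assay, at which 1 of the 3 values shown sits. Even so, nitro in place of chloro on this aromatic carbon gives an at least 2.9-fold higher number from compound 2 to compound 3 (0.46 log units; beyond the scatter). Changes here can therefore move the number up as well as down. Nitro in place of hydroxy on this aromatic carbon gives an at least 1.0-fold higher number from compound 1 to compound 3 (0.01 log units; that floor lies within the scatter), so the lower number of compound 2 does not carry over to every replacement of the hydroxy group of compound 1.

Going by these compounds, how far past the limit compound 3 lies stays open. So does how an amine or a carboxylic acid on this aromatic carbon would compare with chloro.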